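Para-fluoro on the benzamido ring of compound 2

The compounds below may be only part of what the source reports. "The series", "measured", "known", "first", "only" and "open" are said of these compounds alone.

Two compounds of this series have numbers in a functional assay on HCT-116 cells (Homo sapiens) for cytotoxicity, read by sulforhodamine B assay, with a stated time of 48 h; a higher number here means a weaker inhibitor, a lower number a stronger inhibitor. Compound 1 `CCCCNC(=O)N1Cc2c(NC(=O)c3ccccc3)nn(C(=O)C3CC3)c2C1` gives 3470 nM. Compound 2 `CCCCNC(=O)N1Cc2c(NC(=O)c3ccccc3)nn(C(=O)c3ccccc3)c2C1` gives 7470 nM. Among the measured compounds shown here, the one step measured so far, a 2.2-fold higher number from compound 1 to compound 2 (0.33 log units; beyond the scatter), is the only guide to how the series responds to a structural change. Compound 2 therefore stands at the higher of the two numbers, with compound 1 as its nearest neighbour.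

Compound 3 `CCCCNC(=O)N1Cc2c(NC(=O)c3ccc(F)cc3)nn(C(=O)c3ccccc3)c2C1` differs from compound 2 in one place: fluoro in place of hydrogen on an aromatic carbon. For the measured compounds named here, this change sits on the benzamido ring, not on the carbonyl carbon where the one measured step was taken, so that step does not bear on it directly; no measured pair shows what fluoro in place of hydrogen on an aromatic carbon does. With nothing to point either way, the expected step of a 1.1-fold lower number from compound 2 to compound 3 (0.03 log units; within the scatter) is none beyond the scatter. Compound 3 is therefore estimated at 7000 nM, with a range from 2500 nM to 20000 nM.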

Compound 3, half-maximal inhibitory concentration: 30800 nM
Compound 3: middle estimate off by 4.4-fold (0.64 log units), on the low side; measured number outside the range, above it.
By their numbers in this assay, from the lowest: compound 1; then compound 2; then compound 3.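

In this assay, among the compounds shown here, the swap of fluoro for hydrogen gives a 4.1-fold higher number from compound 2 to compound 3 (0.62 log units; beyond the scatter) and so provides the first reading on the benzamido ring: a single fluorine atom, para to a large group, is enough to leave a weaker inhibitor. Together with a 2.2-fold higher number from compound 1 to compound 2 (0.33 log units; beyond the scatter) at the other carbonyl, this means that two separate places on the shared core now respond beyond the scatter, and in both steps the number rises. No measurement on hand offers an explanation for the rise seen with fluoro.

From the compounds shown here alone, whether this rise is particular to fluoro or follows from any group at this place remains open, and chloro, methoxy or a dimethylamino group on the benzamido ring would help to separate those readings. Also open, going by these compounds, is whether the fluoro step holds with cyclopropyl in place of phenyl on the other carbonyl, and how a longer chain than butyl would read against these compounds.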